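The compounds below may be only part of what the source reports. "The series", "measured", "known", "first", "only" and "open" are said of these compounds alone.

Compound 1 `CCCCc1ccc(CNC(=O)Nc2ccccc2)c(=O)n1Cc1ccc(-c2ccccc2-c2nn[nH]n2)cc1`, 30 nM
Compound 2 `CCCCNC(=O)NCc1ccc(CCCC)n(Cc2ccc(-c3ccccc3-c3nn[nH]n3)cc2)c1=O`, 10 nM
Compound 3 `CCCCc1ccc(CNS(C)(=O)=O)c(=O)n1Cc1ccc(-c2ccccc2-c2nn[nH]n2)cc1`, 2 nM

In a functional assay (aorta) for antagonist activity, with Oryctolagus cuniculus as the target (on this read-out higher numbers stand for weaker inhibition and lower numbers for stronger inhibition), compound 1 gives 30 nM, the highest of the three numbers; the nearest is compound 2 with 10 nM and the furthest compound 3 with 2 nM. Compound 4 `CCCCc1ccc(CN(C)S(=O)(=O)c2ccccc2)c(=O)n1Cc1ccc(-c2ccccc2-c2nn[nH]n2)cc1` differs from compound 1 by methyl(phenylsulfonyl)amino in place of (phenylcarbamoyl)amino on a saturated chain carbon bound to an aromatic carbon. Among the measured compounds shown here, two measured steps bear on it: replacing the urea-type group by a sulfonyl group gave a 15-fold lower number from compound 1 to compound 3 (1.18 log units; beyond the scatter), and a 5.0-fold lower number from compound 2 to compound 3 (0.70 log units; beyond the scatter) points the same way, while a 3.0-fold lower number from compound 1 to compound 2 (0.48 log units; beyond the scatter) was smaller. For the measured compounds named here, a step toward lower numbers is therefore expected for compound 4, though the methyl and phenyl on the sulfonyl side have no measured counterpart, so the estimate is a 5.0-fold lower number from compound 1 to compound 4 (0.70 log units; beyond the scatter). Compound 4 is estimated at 6 nM, within a range of 1.5 nM to 25 nM.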

Compound 4, half-maximal inhibitory concentration: 2 nM
Estimate against measurement, compound 4: 3.0-fold (0.48 log units) above; the range from low to high includes it.
By their numbers in this assay, from the lowest: compounds 3 and 4 (each within the scatter of the next); then compound 2; then compound 1.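

In this assay, the gain at this saturated chain carbon is not limited to the small methanesulfonamido group: methyl(phenylsulfonyl)amino gives a 15-fold lower number from compound 1 to compound 4 (1.18 log units; beyond the scatter) and a 5.0-fold lower number from compound 2 to compound 4 (0.70 log units; beyond the scatter). Against methanesulfonamido it shows no change at the digits printed from compound 3 to compound 4 (within the scatter), so a group with a phenyl ring and no hydrogen-bond donors serves as well here. Nothing available explains this result.

Open, on these data alone, is what phenylsulfonylamino, without the methyl on nitrogen, would give, which would separate the methyl from the phenyl. So is the reading with a longer chain on the sulfonyl, such as butylsulfonyl.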